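This account rests on a few compounds, and the source may have more. Where it says the series, first, only, none or still open, it means among the compounds named here.

Measured compounds in an assay on cells for displacement of a labelled ligand from adenosine receptor A3 (Homo sapiens), read by scintillation counting, with a stated time of 3 h; on this read-out higher numbers stand for weaker inhibition and lower numbers for stronger inhibition:
- compound 1, `CC(C)COc1ccc(-c2cn3c(=O)n(-c4ccccc4)nc3c(N)n2)cc1`: "not determined" (no result reported)
- compound 2, `CCCOc1ccc(-c2cn3c(=O)n(-c4ccccc4)nc3c(N)n2)cc1`: > 30000 nM, a limit of the assay
- compound 3, `COc1ccc(-c2cn3c(=O)n(-c4ccccc4)nc3c(=O)[nH]2)cc1`: > 30000 nM, a limit of the assay

Compound 1 has no number in this assay; the only results around it are the two limits. Compound 2 is given only as a limit in this assay. Compound 3 likewise sits at a limit in this assay. So the series rests on (the limit of > 30000 nM in this assay, at which 2 of the 3 values shown sit), and nothing places compound 1 anywhere on a scale.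

Compound 4, `C#CCOc1ccc(-c2cn3c(=O)n(-c4ccccc4)nc3c(N)n2)cc1`, is the next compound in this assay. It differs from compound 1 by ethynyl in place of isopropyl on a saturated chain carbon bound to an oxygen on an aromatic ring. Among the measured compounds shown here, no measured step exists to set the size of this change, and with both neighbours at the limit no direction can be read from them. The expectation is that the step from compound 1 to compound 4 in this assay stays within the usual scatter, with no clear direction, and that compound 4 most likely also ends as a limit. Compound 4 is estimated at 30000 nM, in the range 3000 nM to 100000 nM.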

Compound 4, inhibition constant: > 30000 nM
Compound 4 was reported as a limit (the forecaster's own chance of this, stated with the estimate: 65%); the middle value sits exactly at the limit.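

No new step can be read: compound 2 and compound 4 both stand only as limits in this assay, so the change from ethyl to ethynyl has no readable size: the limit of > 30000 nM in this assay, at which 3 of the 4 values shown sit.

The compounds shown leave open whether any group in this place gives a measurable value in this assay.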